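This account rests on a few compounds, and the source may have more. Where it says the series, first, only, none or still open, it means among the compounds named here.

Measured so far, in a functional assay on MCF7 cells (Homo sapiens) for inhibition, read by CCK-8 assay, with a stated time of 48 h; on this read-out higher numbers stand for weaker inhibition and lower numbers for stronger inhibition:

Compound 1, `Cc1ccc(NC(=S)NC(=O)c2cn(-c3ccccc3)nc2-c2ccc(C)cc2)cc1`, gives 5660 nM.
Compound 2, `COc1ccc(-c2nn(-c3ccccc3)cc2C(=O)NC(=S)Nc2ccc(F)cc2)cc1`, gives 4990 nM.
Compound 3, `Cc1ccc(NC(=S)NC(=O)c2cn(-c3ccccc3)nc2-c2ccccc2)cc1`, gives 5900 nM.

Compound 3 sits together with the other two: all three numbers in this assay lie within the scatter of one another, so none of them can be called stronger or weaker than the rest. Among the compounds with values here, the one step recorded among them, a 1.0-fold higher number from compound 1 to compound 3 (0.02 log units; within the scatter), shows that swapping a methyl for a hydrogen on the same ring left the number where it was.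

Compound 4, `COc1ccc(-c2nn(-c3ccccc3)cc2C(=O)NC(=S)Nc2ccc(C)cc2)cc1`, has not been measured. It differs from compound 3 in one place: methoxy in place of hydrogen on an aromatic carbon. Within the data shown here, no measured pair isolates exactly this change. The closest hint is compound 2, which carries the same methoxy group and a different group on the far ring, and its value in this assay is indistinguishable from those of compound 1 and compound 3. Since nothing measured here moved the number beyond the scatter, the step of a 1.1-fold lower number from compound 3 to compound 4 (0.03 log units; within the scatter) is expected to be small or absent. Compound 4 is therefore estimated at 5500 nM, most likely between 2500 nM and 12000 nM.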

Compound 4, half-maximal inhibitory concentration: 4630 nM
Estimate against measurement, compound 4: 1.2-fold (0.07 log units) above, and the stated range covers the measured number.
By their numbers in this assay, from the lowest: compounds 4, 2, 1 and 3 (each within the scatter of the next).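

In this assay, this ring has now carried hydrogen, methyl and methoxy, and the change from phenyl to 4-methoxyphenyl gives a 1.3-fold lower number from compound 3 to compound 4 (0.11 log units; within the scatter). Methoxy in place of methyl on the same ring gives a 1.2-fold lower number from compound 1 to compound 4 (0.09 log units; within the scatter), while methyl in place of fluoro on the other substituted ring gives a 1.1-fold lower number from compound 2 to compound 4 (0.03 log units; within the scatter), so none of these small groups has moved the number beyond the scatter at either place. Nothing available explains why the number stays put across these changes.

On these data alone, it remains open whether an amine, a carboxylic acid or a longer chain on this aromatic carbon would shift the number at all. Also open, as far as these compounds go, is whether a change to the unsubstituted phenyl group shared by all four compounds would matter.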